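Replacing the acetylthiophene in a weak growth inhibitor

This account rests on a few compounds, and the source may have more. Where it says the series, first, only, none or still open, it means among the compounds named here.

Compound 1 `Cc1ccc(-c2cncc(Cl)c2N2CCC3(CCNC3=O)CC2)o1`: 4950 nM
Compound 2 `CC(=O)c1sccc1-c1cncc(Cl)c1N1CCC2(CCNC2=O)CC1`: > 100000 nM (a limit of the assay, not a number)

Both results come from a functional assay on MV4-11 cells (Homo sapiens) for inhibition, read by resazurin assay, with a stated time of 72 h; on this read-out higher numbers stand for weaker inhibition of growth and lower numbers for stronger inhibition of growth. Compound 2 stands only at the limit of > 100000 nM in this assay, at which 1 of the 2 values shown sits. In compound 3 `Cn1cc(-c2cncc(Cl)c2N2CCC3(CCNC3=O)CC2)cn1`, 1-methyl-1H-pyrazol-4-yl takes the place of 2-acetylthiophen-3-yl on an aromatic carbon (1-methyl-1H-pyrazol-4-yl in place of 2-acetylthiophen-3-yl on an aromatic carbon). Among the compounds with values here, the one measured step that bears on this is an at least 20-fold higher number from compound 1 to compound 2 (1.30 log units; beyond the scatter), a large step that brought in 2-acetylthiophen-3-yl in place of 5-methylfuran-2-yl. Removing that group should undo much of this rise, so a large move to a lower number, meaning stronger inhibition, is expected in this assay. The expected change is an at least 10-fold lower number from compound 2 to compound 3 (1.00 log units; beyond the scatter). Compound 3 is estimated at 10000 nM, with an expected range of 2000 nM to 50000 nM.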

Compound 3, concentration for 50% growth inhibition: 5530 nM
For compound 3 the middle estimate is 1.8-fold (0.26 log units) above the measured one, within the range that was stated.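

Placing 1-methyl-1H-pyrazol-4-yl on this aromatic carbon gives, in this assay, an at least 18-fold lower number from compound 2 to compound 3 (1.25 log units; beyond the scatter). Compound 2 stands at a limit of the assay, not at a number: the limit of > 100000 nM in this assay, at which 1 of the 3 values shown sits.
Two different five-membered aromatic rings are tolerated about equally here, with a 1.1-fold higher number from compound 1 to compound 3 (0.05 log units; within the scatter), so among these three compounds the loss of growth inhibition appears only with 2-acetylthiophen-3-yl.

As far as these compounds go, what stays open is whether the acetyl group or the thiophene ring accounts for that loss, which a plain thiophen-3-yl group could separate. From the compounds shown here alone, it is also open whether a phenyl ring or an amine at this carbon would give stronger inhibition.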